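The compounds below may be only part of what the source reports. "The series", "measured", "known", "first", "only" and "open" are said of these compounds alone.

Three ureas have so far been measured in an ADME assay on the whole organism with Oryza sativa as the target, tested at 1 uM; on this read-out lower numbers stand for a stronger effect and higher numbers for a weaker effect at the one concentration tested. Compound 1 `CC(C)c1ccccc1NC(=O)N[C@H](C)c1ccccc1` gives 101% in this assay. Compound 3 `C[C@@H](NC(=O)Nc1ccccc1C(F)(F)F)c1ccccc1` differs from compound 1 by trifluoromethyl in place of isopropyl on an aromatic carbon; in this assay compound 3 gives 95%, and the step is a number 6 percentage points lower from compound 1 to compound 3 (within the scatter). Compound 2 `CC(C)c1cccc(NC(=O)N[C@H](C)c2ccccc2)c1` has the same atoms as compound 1 joined differently; the difference between the two cores is not broken down here. In this assay compound 2 gives 61%, the lowest of the three numbers, with compound 3 and compound 1 both lying beyond the scatter above it, so compound 2 shows the strongest effect of the three.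

Compound 4 `C[C@@H](NC(=O)Nc1cccc(C(F)(F)F)c1)c1ccccc1` has not yet been measured. It differs from compound 2 by trifluoromethyl in place of isopropyl on an aromatic carbon. This is the same kind of change as that from compound 1 to compound 3, though the place is not identical: ortho to a large group in the earlier pair, meta to a large group here. Resting on the earlier step of a number 6 percentage points lower from compound 1 to compound 3 (within the scatter), which stayed within the scatter, a similarly small step is expected, a number 1 percentage points lower from compound 2 to compound 4 (within the scatter). Compound 4 is therefore estimated at 60%, expected to fall between 42% and 78%.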

Compound 4, a percentage reported as activity, at one concentration (the size of the read-out at that concentration, not a potency): 72%
Beside the measured number, compound 4's estimate is 12 percentage points below it, within the range that was stated.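

Within this assay, the swap of isopropyl for trifluoromethyl does not carry over unchanged from one core to the other: on the second core it comes out as a number 11 percentage points higher from compound 2 to compound 4 (beyond the scatter), a modest weakening of the effect at the one concentration tested. Among the compounds shown here, the size and direction of the step therefore depend on the core it is made on, and the two steps are clearly apart: the same change on two cores in this assay, a number 6 percentage points lower (within the scatter) from compound 1 to compound 3 and a number 11 percentage points higher (beyond the scatter) from compound 2 to compound 4, 17 percentage points apart, beyond the scatter of two such steps With only one pair on each core, this does not show why the two steps part, nor how the swap would behave on any further core.

The compounds shown leave open whether other groups in the same place, such as a nitrile, a methoxy group or an amine, would follow the step on one core, the step on the other, or neither. They also leave open whether the gap between the two steps would persist at concentrations other than the one tested.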